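Permeability of a methoxyphenyl analogue in the quinoline series

A few compounds are considered here, and "the series" means these few. Any claim that something is new, unique, unknown or untested is made for them only; others in the source may bear on it.

Compound 1 `CC(C)Cc1ccc2c(NCCCNCc3ccco3)ccnc2c1` is measured in an ADME assay for permeability, using PAMPA, with a stated time of 30 min, at pH 7.4 (a lower number here means that the compound crosses the layer more slowly, a higher number that the compound crosses the layer faster), and gives 23 10^-6 cm/s. Compound 3 `COc1ccc(F)cc1CNCCCNc1ccnc2cc(CC(C)C)ccc12` gives 23 10^-6 cm/s, which is level with compound 1; these two are together the lowest of the three numbers. Compound 2 `COc1cccc(CNCCCNc2ccnc3cc(Oc4ccc(F)cc4)ccc23)c1O` gives 317 10^-6 cm/s, a markedly higher number, but compound 2 differs from compound 1 in more than one place, so only the two values themselves can be compared. Going by the values given here, the one single-point step measured, no change at the digits printed from compound 1 to compound 3 (within the scatter), concerns the group on the saturated chain carbon bound to the amine nitrogen and leaves the core untouched.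

Compound 4 `COc1ccc(-c2ccc3c(NCCCNCc4ccco4)ccnc3c2)cc1` differs from compound 1 by 4-methoxyphenyl in place of isobutyl on an aromatic carbon. Among the compounds with values here, no measured step alters the group on this aromatic carbon of the core, so the expectation rests on compound 2 alone, whose value 317 10^-6 cm/s shows that a substituent of another kind at the core can go with a high number. The estimated step is a 2.2-fold higher number from compound 1 to compound 4 (0.34 log units; beyond the scatter), expected to lie toward a higher number but without firm support. Compound 4 is therefore estimated at 50 10^-6 cm/s, within 15 10^-6 cm/s to 170 10^-6 cm/s.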

Compound 4, apparent permeability: 237 10^-6 cm/s
Compound 4: middle estimate off by 4.7-fold (0.68 log units), on the low side; measured number above the stated range.
By their numbers in this assay, from the lowest: compounds 1 and 3 (each within the scatter of the next); then compounds 4 and 2 (each within the scatter of the next).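

In this assay the aromatic carbon of the core proves to be a place where the number can move a long way, and 4-methoxyphenyl in place of isobutyl gives a 10-fold higher number from compound 1 to compound 4 (1.01 log units; beyond the scatter) in a single change. Going by these compounds alone, the only earlier single-point step, no change at the digits printed from compound 1 to compound 3 (within the scatter), lay on the saturated chain carbon, and compound 2 differs from compound 1 in more than one place, so neither showed what a change at this carbon does on its own with the furan-2-yl group held constant. No evidence is available that bears on the reason for this step.

The compounds shown leave open whether a plain phenyl or a morpholine on this aromatic carbon would go with a similarly high number. They also leave open whether the same change would give a step of this size with the 5-fluoro-2-methoxyphenyl group of compound 3 in place of furan-2-yl.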